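The source may report more compounds than this note shows. Statements on the series, on what has been measured and on what is new or still open speak of the compounds shown alone.

In a functional assay on HepG2 cells (Homo sapiens) for antiproliferative activity, read by MTT assay, with a stated time of 48 h (on this read-out lower numbers stand for stronger inhibition and higher numbers for weaker inhibition), compound 1 `O=C(CN1CCCCC1)Nc1ccc2ncnc(Nc3cccc(C(F)(F)F)c3)c2c1` reaches only the limit of the assay, > 100000 nM. Compound 2 `CN1CCN(CC(=O)Nc2ccc3ncnc(Nc4cccc(C(F)(F)F)c4)c3c2)CC1` likewise gives only a limit, > 100000 nM. Compound 3 `O=C(CN1CCCCC1)Nc1ccc2ncnc(Nc3cccc(Br)c3)c2c1` gives a number, 16000 nM. The change bromo in place of trifluoromethyl on an aromatic carbon brought an at least 6.2-fold lower number from compound 1 to compound 3 (0.79 log units; beyond the scatter). The change 4-methylpiperazin-1-yl in place of piperidin-1-yl on a saturated chain carbon bound to a carbonyl carbon produced a step that the two limits leave unreadable from compound 1 to compound 2, since both values sit at the limit of > 100000 nM in this assay, at which 2 of the 3 values shown sit.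

Compound 4 `CN1CCN(CC(=O)Nc2ccc3ncnc(Nc4cccc(Br)c4)c3c2)CC1` has not yet been measured. It differs from compound 3 by 4-methylpiperazin-1-yl in place of piperidin-1-yl on a saturated chain carbon bound to a carbonyl carbon, the same change that was made from compound 1 to compound 2, on the same place. The two cores differ by bromo in place of trifluoromethyl on an aromatic carbon. The earlier step gives no readable size, so from compound 3 to compound 4 a small step, a 1.3-fold higher number from compound 3 to compound 4 (0.10 log units; within the scatter), is expected, resting only on the value of compound 3, 16000 nM. Compound 4 is accordingly estimated at 20000 nM, between 6000 nM and 80000 nM.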

Compound 4, half-maximal inhibitory concentration: 25300 nM
Compound 4: the middle estimate sits 1.3-fold (0.10 log units) below what was measured; measured number inside the range.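

Bromo in place of trifluoromethyl on an aromatic carbon brought an at least 3.9-fold lower number from compound 2 to compound 4 (0.59 log units; beyond the scatter), so the direction seen on the core with piperidin-1-yl carries over to the core with 4-methylpiperazin-1-yl, though no size can be compared: the same change on two cores in this assay, an at least 6.2-fold lower number (0.79 log units; beyond the scatter) from compound 1 to compound 3 and an at least 3.9-fold lower number (0.59 log units; beyond the scatter) from compound 2 to compound 4; the limit leaves it open whether they differ

4-methylpiperazin-1-yl in place of piperidin-1-yl gave a 1.6-fold higher number from compound 3 to compound 4 (0.20 log units; within the scatter), whereas the same change on the trifluoromethyl core cannot be read. Compound 1 and compound 2 both give only a limit, so these pairs do not show whether that change carries over: the limit of > 100000 nM in this assay, at which 2 of the 4 values shown sit.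

The compounds shown leave open what a chloro or methoxy group would do on the aromatic carbon that holds bromo. They also leave open how an open-chain amine such as dimethylamino or a longer chain would compare with the two rings.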